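Amino in place of hydrogen on compound 1: expected cytotoxicity

A few compounds are considered here, and "the series" means these few. Any claim that something is new, unique, unknown or untested is made for them only; others in the source may bear on it.

Compound 1 `CCn1cc(-c2nc3ccccc3[nH]2)c(=O)c2cc(F)c(N3CCNCC3)cc21` gives in a functional assay on AGS cells (Homo sapiens) for cytotoxicity, read by sulforhodamine B assay, with a stated time of 48 h (a lower number here means a stronger inhibitor, a higher number a weaker inhibitor), only a limit, > 10000 nM, not a number; it sits at the limit of > 10000 nM in this assay, at which 1 of the 2 values shown sits. Compound 2 `CCn1cc(-c2nc3ccc([N+](=O)[O-])cc3s2)c(=O)c2cc(F)c(N3CCN(C)CC3)cc21` is the other measured member and gives 4500 nM in this assay; the two differ in more than one place, so only the two values themselves stand side by side. Compound 3 `CCn1cc(-c2nc3ccc(N)cc3[nH]2)c(=O)c2cc(F)c(N3CCNCC3)cc21` is not yet measured and differs from compound 1 by amino in place of hydrogen on an aromatic carbon. No measured step sizes this change, so no step beyond the scatter is expected in this assay. Compound 3 is estimated at 8000 nM, within 2500 nM to 25000 nM, an expected step of an at least 1.2-fold lower number from compound 1 to compound 3 (0.09 log units; that floor lies within the scatter).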

Compound 3, half-maximal inhibitory concentration: 10000 nM
Estimate against measurement, compound 3: 1.3-fold (0.10 log units) below; the range from low to high includes it.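

In this assay compound 3 gives 10000 nM, so amino in place of hydrogen on an aromatic carbon yields a readable number on the core of compound 1. Compound 1 gives > 10000 nM, which is a limit and not a number. Amino in place of hydrogen on an aromatic carbon gives a number no higher from compound 1 to compound 3 (the limit leaves the size open). The size of the step cannot be read because of that limit: the limit of > 10000 nM in this assay, at which 1 of the 3 values shown sits.

Still open, on these data alone, is whether a carboxylic acid or a methoxy group on the same aromatic carbon would give a lower number than compound 3 does.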